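Methoxy for methyl on the para aryl group

The compounds below may be only part of what the source reports. "The series", "measured", "known", "first", "only" and "open" are said of these compounds alone.

compound 1 `O=c1oc2ccccc2c2nc3c(ccc4cc[nH]c43)c(-c3ccccc3Br)c12`: 70700 nM
compound 2 `Cc1ccc(-c2c3ccc4cc[nH]c4c3nc3c2c(=O)oc2ccccc23)cc1`: 70700 nM

In a functional assay on B16-F10 cells (Mus musculus) for cytotoxicity (a higher number here means a weaker inhibitor, a lower number a stronger inhibitor), compound 1 and compound 2 stand level, with compound 2 at 70700 nM. Compound 3 `COc1ccc(-c2c3ccc4cc[nH]c4c3nc3c2c(=O)oc2ccccc23)cc1` carries methoxy in place of methyl on an aromatic carbon, para to a large group (methoxy in place of methyl on an aromatic carbon). Among the compounds with values here, only one measured step bears on this change, and it is a different substitution: no change at the digits printed from compound 1 to compound 2 (within the scatter). No shift beyond the scatter is therefore expected, and no direction is favoured. The expected step is a 1.2-fold lower number from compound 2 to compound 3 (0.07 log units; within the scatter). For compound 3 the estimated value is 60000 nM, with an expected range of 25000 nM to 110000 nM.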

Compound 3, half-maximal inhibitory concentration: 70700 nM
Beside the measured number, compound 3's estimate is 1.2-fold (0.07 log units) below it; the measured number falls inside the stated range.
By their numbers in this assay, from the lowest: compounds 1, 2 and 3 (each within the scatter of the next).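

In this assay, methoxy in place of methyl on the aromatic carbon para to a large group gives no change at the digits printed from compound 2 to compound 3 (within the scatter). Exchanging the 2-bromophenyl group for 4-methoxyphenyl gives no change at the digits printed from compound 1 to compound 3 (within the scatter), so the hydrogen-bond acceptor entering with methoxy comes with no shift among these three compounds. Nothing available accounts for this flat result.

Open, going by these compounds, is whether any group at this position moves the number, such as an amine, a carboxylic acid or a longer chain in place of methoxy. Also open, on these data alone, is whether changes to the shared core would do so.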